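Trimming the Amide Nitrogen: From Compound 2 to Compound 3

This account rests on a few compounds, and the source may have more. Where it says the series, first, only, none or still open, it means among the compounds named here.

Measured compounds:
compound 1, `Cc1cccc(NC(=O)/C(C#N)=C/c2cc(O)c(O)c([N+](=O)[O-])c2)c1`: 13.1 ug/mL
compound 2, `N#C/C(=C\c1cc(O)c(O)c([N+](=O)[O-])c1)C(=O)Nc1ccccc1Cl`: 24 ug/mL

Within the data shown here, in a functional assay on Bel-7402 cells (Homo sapiens) for antiproliferative activity, read by MTT assay (on this read-out higher numbers stand for weaker inhibition and lower numbers for stronger inhibition), compound 2 gives the highest of the two numbers; its only neighbour is compound 1, and the step of a 1.8-fold higher number from compound 1 to compound 2 (0.26 log units; within the scatter) lies within the scatter. Compound 3, `N#C/C(=C\c1cc(O)c(O)c([N+](=O)[O-])c1)C(N)=O`, has not yet been measured. It differs from compound 2 by hydrogen in place of 2-chlorophenyl on an amide-type nitrogen. Among the measured compounds shown here, the one measured step exchanges one aryl group for another on that nitrogen and hardly moved the number, so it bears on the new change only loosely; no measured step removes the aryl group altogether. The account therefore expects for compound 3 no firm shift beyond the scatter, with a wide range to reflect that gap in the data. Compound 3 is estimated at 30 ug/mL, within 10 ug/mL to 90 ug/mL. This estimate means the step of a 1.3-fold higher number from compound 2 to compound 3 (0.10 log units; within the scatter).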

Compound 3, half-maximal inhibitory concentration: > 100 ug/mL
Compound 3 ended at the assay's limit (the forecaster's own chance of this, stated with the estimate: 10%); middle value at least 3.3-fold (0.52 log units) from the limit.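

In this assay, removing the aryl group from the amide-type nitrogen has an effect that exchanging one aryl group for another did not show: hydrogen in place of 2-chlorophenyl gives an at least 4.1-fold higher number from compound 2 to compound 3 (0.61 log units; beyond the scatter), and hydrogen in place of 3-methylphenyl gives an at least 7.6-fold higher number from compound 1 to compound 3 (0.88 log units; beyond the scatter). Activity at this position therefore depends on what the nitrogen carries, and the unsubstituted amide is clearly weaker than either aryl amide. Compound 3 gives > 100 ug/mL, which is a limit and not a number, so the full size of both steps stays open: the limit of > 100 ug/mL in this assay, at which 1 of the 3 values shown sits.

The compounds shown leave open whether an aromatic ring is needed on this nitrogen or whether a methyl group or a longer alkyl chain would serve as well. They also do not show how a benzyl group or a phenyl ring bearing a carboxylic acid would read in this assay.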